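This account rests on a few compounds, and the source may have more. Where it says the series, first, only, none or still open, it means among the compounds named here.

Compound 1 `C#CCn1cc(C(=O)NC(CC(=O)Nc2ccccc2)c2ccccc2)c(=O)c2cc(F)c(Cl)nc21`: 2100 nM
Compound 2 `C#CCn1cc(C(=O)NC(CC(=O)Nc2ccccc2)c2ccccc2)c(=O)c2cccnc21`: > 10000 nM

Both were tested in a functional assay on PA-1 cells (Homo sapiens) for cytotoxicity, read by MTT assay, with a stated time of 72 h; on this read-out lower numbers stand for stronger inhibition and higher numbers for weaker inhibition. For the measured compounds named here, compound 1 is the only compound here with a number, and compound 1 gives 2100 nM. Compound 2 gives > 10000 nM, which is a limit of the assay rather than a number, namely (the limit of > 10000 nM in this assay, at which 1 of the 2 values shown sits). Compound 3 `C#CCn1cc(C(=O)NC(CC(=O)Nc2ccccn2)c2ccccc2)c(=O)c2cc(F)c(Cl)nc21` differs from compound 1 by pyridin-2-yl in place of phenyl on an amide-type nitrogen. Going by the values given here, no measured pair shows this change, so the step from compound 1 to compound 3 is expected to stay within the usual scatter, as a 1.4-fold higher number from compound 1 to compound 3 (0.15 log units; within the scatter). Compound 3 is estimated at 3000 nM, between 1000 nM and 9000 nM.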

Compound 3, half-maximal inhibitory concentration: > 10000 nM
Compound 3: no number, only a limit (the forecaster's own chance of this, stated with the estimate: 15%); at least 3.3-fold (0.52 log units) between middle value and limit.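

In this assay, pyridin-2-yl in place of phenyl on an amide-type nitrogen gives an at least 4.7-fold higher number from compound 1 to compound 3 (0.67 log units; beyond the scatter). For the compounds shown here, this is the first view of this position, and it shows that exchanging one ring carbon for nitrogen in this phenyl is enough to weaken inhibition beyond the scatter. The value of compound 3 is a limit of the assay and not a number, so the full size of the step stays unknown: the limit of > 10000 nM in this assay, at which 2 of the 3 values shown sit.

Still open, going by these compounds, is how a cyclohexyl ring or a 4-methoxyphenyl group on the same nitrogen would compare with phenyl.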